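A few compounds are considered here, and "the series" means these few. Any claim that something is new, unique, unknown or untested is made for them only; others in the source may bear on it.

Measured so far in a functional assay on NCI-H23 cells (Homo sapiens) for cytotoxicity, read by sulforhodamine B assay, with a stated time of 72 h; a lower number here means a stronger inhibitor of growth, a higher number a weaker inhibitor of growth:

Compound 1 `O=C(Nc1cc(C(F)(F)F)cc(C(F)(F)F)c1)C1CCc2ccccc2N1C(=O)c1ccccc1Cl`: 2080 nM.
Compound 2 `CCCC(=O)N1c2ccccc2CCC1C(=O)Nc1ccccc1C(F)(F)F`: this is a limit of the assay, > 70000 nM.
Compound 3 `O=C(Nc1ccc(O)cc1)C1CCc2ccccc2N1`: this is a limit of the assay, > 100000 nM.

Compound 2 therefore has no exact number; it sits at the limit of > 70000 nM in this assay, at which 1 of the 3 values shown sits, the weakest end of what the assay can report. Only compound 1, with an aroyl group on the ring nitrogen, gives a measured value here. Compound 4 `O=C(Nc1ccccc1C(F)(F)F)C1CCc2ccccc2N1C(=O)c1ccc(Cl)cc1` differs from compound 2 in one place: 4-chlorophenyl in place of propyl on a carbonyl carbon. Going by the values given here, with no measured pair of this kind, the direction is guessed from compound 1, whose value 2080 nM came with an aroyl group in place. A gain beyond the scatter is expected, with the step from an at least 4.6-fold lower number from compound 2 to compound 4 (0.66 log units; beyond the scatter), so compound 4 is estimated at 15000 nM, between 4000 nM and 70000 nM.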

Compound 4, concentration for 50% growth inhibition: 307 nM
Compound 4: middle estimate off by 49-fold (1.69 log units), on the high side; the whole stated range lies above it.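

In this assay, going by these compounds alone, the earlier compounds offered no pair differing in one place, whereas this pair shows that the group on this carbonyl carbon can decide activity: 4-chlorophenyl in place of propyl gives an at least 220-fold lower number from compound 2 to compound 4 (2.35 log units; beyond the scatter). The step has only a lower bound, with compound 2 at a limit of the assay: the limit of > 70000 nM in this assay, at which 1 of the 4 values shown sits.

The compounds shown leave open whether the aromatic ring alone accounts for this step or whether the chlorine is also needed. They also leave open how an unsubstituted phenyl, a pyridine ring or a longer chain would fare on this carbonyl carbon.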